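Swapping chloro for methoxy on the pendant phenyl ring

The source may report more compounds than this note shows. Statements on the series, on what has been measured and on what is new or still open speak of the compounds shown alone.

Measured so far:
- Compound 1 `O=S(=O)(c1ccc(F)c(Cl)c1)c1cnc2c(F)cccc2c1-c1cccc(Cl)c1`: 0.18 mL/min
- Compound 2 `O=S(=O)(c1cccc(F)c1)c1cnc2c(F)cccc2c1-c1cccc(Cl)c1`: 0.56 mL/min
- Compound 3 `O=S(=O)(c1ccc(F)c(F)c1)c1cnc2c(F)cccc2c1-c1cccc(Cl)c1`: 1.13 mL/min

All three share one core and were tested in an ADME assay on microsomes from liver (Homo sapiens) for metabolic stability, tested at 2.5 uM; a higher number here means faster removal of the compound, a lower number slower removal. Compound 2 gives 0.56 mL/min, the second highest of the three numbers; it is nearest to compound 3 with a 2.0-fold higher number from compound 2 to compound 3 (0.30 log units; within the scatter), and furthest from compound 1 with a 3.1-fold higher number from compound 1 to compound 2 (0.49 log units; beyond the scatter). The other step, a 6.3-fold higher number from compound 1 to compound 3 (0.80 log units; beyond the scatter), also lies between these two.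

Compound 4 `COc1cccc(-c2c(S(=O)(=O)c3cccc(F)c3)cnc3c(F)cccc23)c1` has not yet been measured. Its change from compound 2 is methoxy in place of chloro on an aromatic carbon.

Among the compounds with values here, every measured step so far alters the ring on the sulfonyl sulfur, not the ring that changes here. None of them therefore bears directly on the move from compound 2 to compound 4, and nothing in the data shows how this ring answers to a swap of this kind. From the compounds shown here alone, the size of the step is unknown, and the expectation can only be anchored on compound 2 itself, with a wide allowance.

Compound 4 is expected to give about 0.75 mL/min, in a range from 0.3 mL/min to 1.9 mL/min, which means an expected step of a 1.3-fold higher number from compound 2 to compound 4 (0.13 log units; within the scatter).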

Compound 4, intrinsic clearance in a liver preparation (reported as CLH), per the amount of preparation that the assay uses: 2.6 mL/min
Estimate against measurement, compound 4: 3.5-fold (0.54 log units) below; measured number outside the range, above it.
By their numbers in this assay, from the lowest: compound 1; then compounds 2 and 3 (each within the scatter of the next); then compound 4.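

In this assay, within the data shown here, the swap of 3-chlorophenyl for 3-methoxyphenyl gives a 4.6-fold higher number from compound 2 to compound 4 (0.67 log units; beyond the scatter) and this is the first measured step on this ring, so the group at this position does matter for how quickly the compound is removed. Starting from the same compound, the step on the other ring is smaller and stays within the scatter, at a 2.0-fold higher number from compound 2 to compound 3 (0.30 log units; within the scatter) while the methoxy step clears it. Chloro leaves and methoxy enters, which changes the atoms present and adds a hydrogen-bond acceptor, but a single swap cannot separate these differences, and no measurement here speaks to the cause of the rise.

With only chloro and methoxy shown on this ring, it remains open whether a hydroxy group, a methyl group or a longer ethoxy chain at the same place would land nearer compound 2 or nearer compound 4. Among these compounds, it is also open whether the same swap would give a step of similar size with the sulfonyl ring of compound 1 or compound 3 in place of the one in compound 2.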